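Oxetane to Open Chain on a Quinoline Cytotoxicity Series

A few compounds are considered here, and "the series" means these few. Any claim that something is new, unique, unknown or untested is made for them only; others in the source may bear on it.

Measured compounds:
- compound 1 `Cc1ccc2nc(N3CCCc4ccc(F)cc4C3)cc(NCC3(N)COC3)c2c1`: in an ADME assay on HEp-2 cells (Homo sapiens) for cytotoxicity, read by CCK-8 assay, with a stated time of 5 days (on this read-out lower numbers stand for higher toxicity in this test and higher numbers for lower toxicity in this test), the result is a limit, > 100000 nM
- compound 2 `NCCNc1cc(N2CCCc3ccccc3C2)nc2ccccc12`: 23000 nM in this assay

Compound 1 stands only at a limit of this assay, as the limit of > 100000 nM in this assay, at which 1 of the 2 values shown sits, records; no number is known for it. Compound 2 gives a number, 23000 nM, and the two values show nothing more than that, since compound 2 differs from compound 1 in more than one place.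

Compound 3 `Cc1ccc2nc(N3CCCc4ccc(F)cc4C3)cc(NCCN)c2c1` is not yet measured. It differs from compound 1 by aminomethyl in place of 3-aminooxetan-3-yl on a saturated chain carbon bound to a nitrogen on an aromatic ring: the (3-aminooxetan-3-yl)methyl group of compound 1 becomes 2-aminoethyl, so that the ((3-aminooxetan-3-yl)methyl)amino arm turns into the (2-aminoethyl)amino arm carried by compound 2. For the measured compounds named here, no measured step covers this change. For compound 3 a step toward a lower number, hence toward higher toxicity in this test, is expected, of size an at least 2.5-fold lower number from compound 1 to compound 3 (0.39 log units; beyond the scatter), because compound 2, which bears the same 2-aminoethyl chain, gives 23000 nM. Compound 3 is therefore estimated at 40000 nM, within 15000 nM to 110000 nM.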

Compound 3, half-maximal cytotoxic concentration: > 3200 nM
Compound 3 gave a limit, no number; the forecaster's own chance of this, stated with the estimate: 35%; the middle value is on the limit's open side.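

In this assay, for the compounds shown here, compound 1 and compound 3 both stand only at limits, not at numbers, and no step between the two can be read. The compounds shown leave open what number compound 3 would give, and whether aminomethyl in place of 3-aminooxetan-3-yl changes the read-out at all.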